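Methoxy to Ethoxy on a Vanilloid Receptor Antagonist

The source may hold more compounds than are shown below. What is called first, only, known or untested is meant among the compounds shown, and "the series" means these compounds.

Measured compounds:
Compound 1 `Cc1cc(CN/C(S)=N/Cc2ccc(NS(C)(=O)=O)cc2)c(COC(=O)C(C)(C)C)cc1C` gives 70000 nM in a functional assay for inhibition of Vanilloid receptor (Rattus norvegicus); on this read-out lower numbers stand for stronger inhibition and higher numbers for weaker inhibition.
Compound 2 `COc1cc(C(C)(C)C)ccc1C/N=C(\S)NCc1ccc(NS(C)(=O)=O)cc1` gives 2400 nM in this assay.

Within the data shown here, of these two numbers, compound 2 has the lower one, and the gap to compound 1 lies beyond the usual scatter; the two structures differ in several places, so no single step links them. Compound 3 `CCOc1cc(C(C)(C)C)ccc1C/N=C(\S)NCc1ccc(NS(C)(=O)=O)cc1` is not yet measured. It differs from compound 2 by methyl in place of hydrogen on a saturated chain carbon bound to an oxygen on an aromatic ring. Among the measured compounds shown here, with no measured pair showing a change of this kind, there is nothing in the data to set a direction. A change of this size is expected to move this assay little, if at all, beyond the scatter. Compound 3 is therefore estimated to give 2200 nM, with a range from 700 nM to 7000 nM. The step this estimate implies, a 1.1-fold lower number from compound 2 to compound 3 (0.04 log units; within the scatter), is expected to stay within the scatter.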

Compound 3, half-maximal inhibitory concentration: 1100 nM
Compound 3: the middle estimate sits 2.0-fold (0.30 log units) above what was measured, and the stated range covers the measured number.
By their numbers in this assay, from the lowest: compound 3; then compound 2; then compound 1.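

Methoxy to ethoxy, which places methyl on a saturated chain carbon bound to an oxygen on an aromatic ring, gives a 2.2-fold lower number from compound 2 to compound 3 (0.34 log units; beyond the scatter) in this assay as a modest step. Among these compounds, compound 1 and compound 2 differ in several places, so this is the first step here that can be read at a single place. It shows that this position accepts the added methyl without any loss in this read-out, and that the number moves to the lower side. Nothing available gives a cause for this step. On these data alone, whether the trend continues with a longer chain such as propoxy, or with a branched isopropoxy, remains open, since one step sets no trend. Also open, as far as these compounds go, is how a hydroxyl or an amine would read at this place.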